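Ester in place of ether on the side-chain oxygen

A few compounds are considered here, and "the series" means these few. Any claim that something is new, unique, unknown or untested is made for them only; others in the source may bear on it.

Compound 3 `CCC(CO[C@H](CC=C(C)C)C1=CC(=O)c2c(O)ccc(O)c2C1=O)OC(C)=O` gives 44000 nM in a functional assay on HeLa cells (Homo sapiens) for cytotoxicity, read by MTT assay; a lower number here means a stronger inhibitor, a higher number a weaker inhibitor. Its number sits at the top of the three shown, yet every gap to the others lies within the scatter: compound 1 `CC(=O)OCCO[C@H](CC=C(C)C)C1=CC(=O)c2c(O)ccc(O)c2C1=O` gives 41500 nM, and a 1.1-fold higher number from compound 1 to compound 3 (0.03 log units; within the scatter); compound 2 `CCC(O)CO[C@H](CC=C(C)C)C1=CC(=O)c2c(O)ccc(O)c2C1=O` gives 28700 nM, and a 1.5-fold higher number from compound 2 to compound 3 (0.19 log units; within the scatter). Compound 4 `CCCCC(C)(O)CC(=O)O[C@H](CC=C(C)C)C1=CC(=O)c2c(O)ccc(O)c2C1=O` has not yet been measured in this assay. The change from compound 3 is this: (2-hydroxy-2-methylhexyl)carbonyl in place of 2-acetoxybutyl on an oxygen on a saturated carbon. Among the measured compounds shown here, two measured steps bear on it. The step of a 1.5-fold higher number from compound 2 to compound 3 (0.19 log units; within the scatter) shows that acetyl in place of hydrogen on an oxygen on a saturated carbon leaves the number where it was, and the step of a 1.4-fold lower number from compound 1 to compound 2 (0.16 log units; within the scatter) shows the same for 1-hydroxypropyl in place of acetoxymethyl. Compound 4 brings in a (2-hydroxy-2-methylhexyl)carbonyl with 1 hydrogen-bond donor, but none of the three steps shown exceeds the scatter, so no step beyond the scatter is expected: a 1.2-fold lower number from compound 3 to compound 4 (0.06 log units; within the scatter). Compound 4 is therefore estimated at 38000 nM, between 16000 nM and 90000 nM.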

Compound 4, half-maximal inhibitory concentration: 60600 nM
Estimate against measurement, compound 4: 1.6-fold (0.20 log units) below; measured number inside the range.
By their numbers in this assay, from the lowest: compounds 2, 1, 3 and 4 (each within the scatter of the next, the first and the last beyond it).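

Among the compounds shown here, measured against 2-hydroxybutyl, (2-hydroxy-2-methylhexyl)carbonyl gives a 2.1-fold higher number from compound 2 to compound 4 (0.32 log units; beyond the scatter) in this assay and is the only step beyond the scatter, though a modest one. In place of 2-acetoxybutyl the same group gives a 1.4-fold higher number from compound 3 to compound 4 (0.14 log units; within the scatter) and in place of 2-acetoxyethyl it gives a 1.5-fold higher number from compound 1 to compound 4 (0.16 log units; within the scatter) so this position takes a group with a carbonyl on the oxygen and only the comparison with the free hydroxyl of compound 2 separates the numbers. No measurement on hand accounts for that one separation.

The compounds shown leave open whether an amine or a carboxylic acid on this side chain would move the number further. They also leave open how a longer chain without the hydroxyl of compound 4 would compare with compound 4 itself.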